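Aryloxyacetamide TRPM8 agonists: from isopropyl to methoxy

This account rests on a few compounds, and the source may have more. Where it says the series, first, only, none or still open, it means among the compounds named here.

Compound 1: `CCN(Cc1cccs1)C(=O)C(C)Oc1ccc(C)cc1`, 889 nM
Compound 2: `CCN(Cc1cccs1)C(=O)COc1ccc(C(C)C)cc1`, 397 nM
Compound 3: `Cc1ccc(OCC(=O)N(Cc2cccs2)C2CCCCC2)cc1`, 40000 nM

Of the compounds shown here, three sharing a thiophene-methyl amide core have been measured in an assay on HEK293 cells for agonist activity at transient receptor potential cation channel subfamily M member 8 (Homo sapiens), read by fluorescence and calcium flux, with a stated time of 15 min; a lower number here means that less compound is needed, a higher number that more compound is needed for the effect. Compound 2, which carries an isopropyl group on the phenyl ring, gives the lowest number of the three with 397 nM. Compound 1, with its methyl-bearing ring and an added methyl on the carbon next to the carbonyl, sits at 889 nM, a step that lies beyond the scatter. Compound 3, in which a cyclohexyl group replaces the ethyl on the amide nitrogen, is far weaker in this assay at 40000 nM, a step well beyond the scatter from compound 2.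

The next compound, compound 4, is `CCN(Cc1cccs1)C(=O)COc1ccc(OC)cc1`. It differs from compound 2 in a single place:

methoxy in place of isopropyl on an aromatic carbon

Going by the values given here, no pair of measured compounds isolates this change, so the expectation rests on compound 2 alone. Because compound 2 gives 397 nM, a moderate rise in the number is anticipated, of a size beyond the scatter, so that compound 4 is expected to need somewhat more compound for the effect. The estimated step from compound 2 is a 5.0-fold higher number from compound 2 to compound 4 (0.70 log units; beyond the scatter). Compound 4 is therefore expected to give about 2000 nM in this assay, within a range from 500 nM to 8000 nM.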

Compound 4, half-maximal effective concentration: 120 nM
Compound 4: middle estimate off by 17-fold (1.22 log units), on the high side; measured number below the stated range.
By their numbers in this assay, from the lowest: compound 4; then compound 2; then compound 1; then compound 3.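

In this assay, going by these compounds alone, methoxy in place of isopropyl on an aromatic carbon, para to a large group, gives a 3.3-fold lower number from compound 2 to compound 4 (0.52 log units; beyond the scatter), the first step here between compounds that differ in one place. It shows that this position does not need isopropyl, with its 3 heavy atoms and 0 hydrogen-bond acceptors, to reach a low number: methoxy, with 2 heavy atoms and 1 hydrogen-bond acceptor, gives a lower one, and the heteroatom-bearing group is the better of the two at this position. Nothing measured here accounts for why this swap lowers the number.

As far as these compounds go, with only these two groups compared at this position, it remains open how others would behave there, such as ethoxy, a hydroxyl, a dimethylamino group or a longer alkyl chain, and so whether the lower number follows the oxygen or some other difference between the groups. From the compounds shown here alone, it is also open whether methoxy would bring a similar step on the background of compound 1, with its added methyl on the carbon next to the carbonyl, or of compound 3, with its cyclohexyl group on the amide nitrogen.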